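A few compounds are considered here, and "the series" means these few. Any claim that something is new, unique, unknown or untested is made for them only; others in the source may bear on it.

Compound 1, `O=Cc1ccc(-c2cn3ccnc3c(-c3ccc4ncn(C5CCCCC5)c4c3)n2)cc1`, gives 51.2% in a functional assay on MDA-MB-231 cells (Homo sapiens) for inhibition, read by sulforhodamine B assay, with a stated time of 48 h, tested at 10 uM; a lower number here means less inhibition, a higher number more inhibition at the concentration tested (going by the name of the read-out).
Compound 2, `c1cn2cc(-c3ccsc3)nc(-c3ccc4ncn(C5CCCCC5)c4c3)c2n1`, gives 1.35% in this assay.
Compound 3, `CC(=O)c1ccc(-c2cn3ccnc3c(-c3ccc4ncn(C5CCCCC5)c4c3)n2)cc1`, gives 7.65% in this assay.

Among these three, compound 1 stands highest. Its nearest neighbour is compound 3, reached by a step of a number 43.6 percentage points lower from compound 1 to compound 3 (beyond the scatter), and its furthest is compound 2, reached by a number 49.9 percentage points lower from compound 1 to compound 2 (beyond the scatter). Compounds 2 and 3 sit close together, since a number 6.3 percentage points higher from compound 2 to compound 3 (within the scatter).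

Compound 4, `Clc1ccc(-c2cn3ccnc3c(-c3ccc4ncn(C5CCCCC5)c4c3)n2)cc1`, differs from compound 1 by one change: chloro in place of formyl on an aromatic carbon. Among the measured compounds shown here, two measured steps bear on this. The step from compound 1 to compound 3, where only a methyl was added on the carbonyl carbon, already cost a number 43.6 percentage points lower from compound 1 to compound 3 (beyond the scatter), so the formyl group seems to be easily disturbed. The step from compound 1 to compound 2, where the whole 4-formylphenyl arm was exchanged, cost a number 49.9 percentage points lower from compound 1 to compound 2 (beyond the scatter). Exchanging the formyl for a chloro removes the carbonyl entirely, which neither measured step does exactly, so the outcome is uncertain, but a large drop in this assay is expected, in the same direction as both steps.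

Compound 4 is therefore estimated at 12%, within a range from 0% to 45%, which is an expected step of a number 39.2 percentage points lower from compound 1 to compound 4 (beyond the scatter).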

Compound 4, a percentage reported as inhibition, at one concentration (the size of the read-out at that concentration, not a potency): 15.3%
Compound 4: middle estimate off by 3.3 percentage points, on the low side; low and high end bracket the measured number.
By their numbers in this assay, from the lowest: compounds 2, 3 and 4 (each within the scatter of the next, the first and the last beyond it); then compound 1.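

Exchanging formyl for chloro on this aromatic carbon, para to a large group, gives a number 35.9 percentage points lower from compound 1 to compound 4 (beyond the scatter) in this assay, so the drop seen earlier with the acetyl group also appears with a group that has no carbonyl at all, even though the phenyl ring stays in place. Chloro and acetyl cannot be told apart here, with a number 7.7 percentage points higher from compound 3 to compound 4 (within the scatter), which leaves formyl as the only group on this phenyl ring that lifts the number to the level of compound 1, while the 4-chlorophenyl arm still shows a number 14 percentage points higher from compound 2 to compound 4 (beyond the scatter), a modest gap over thiophen-3-yl. Nothing available explains why the formyl compound stands apart from the others.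

The compounds shown leave open whether a carboxylic acid, a hydroxymethyl group or a nitrile on this same carbon would stay near compound 1 or fall to the level of compound 3 and compound 4. They also leave open how these compounds would rank by potency, as each number is a reading at one concentration, not a full dose-response curve.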